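Compound 3 and its ring-carbon stereoisomer, compound 4

The source may report more compounds than this note shows. Statements on the series, on what has been measured and on what is new or still open speak of the compounds shown alone.

Measured in an ADME assay on liver for metabolic stability, with Liver microsome (Homo sapiens) as the target, read by LC-MS, using microsomes, with a stated time of 5 h (a higher number here means faster removal of the compound, a lower number slower removal), for three compounds
- Compound 1 `OC(c1ncccn1)C1(c2ccc(OC(F)(F)F)cc2)CCC1` gives 100 mL/min/kg
- Compound 2 `O[C@H](c1ccccn1)[C@]1(c2cccc(OC(F)(F)F)c2)C[C@@H](O)C1` gives 117 mL/min/kg
- Compound 3 `O[C@@]1(c2ccccn2)CC[C@@H](c2ccc(C(F)(F)F)cc2)C1` gives 150 mL/min/kg

Compound 3 at 150 mL/min/kg stands within the scatter of both other compounds, so the three values form a single band and no order can be read among them. No two of these compounds differ in only one place, so no measured step isolates a single change.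

Compound 4 `O[C@]1(c2ccccn2)CC[C@@H](c2ccc(C(F)(F)F)cc2)C1` has no value yet. Its difference from compound 3 is the two compounds have the same atoms and bonds and differ only in configuration as drawn: 1 of 2 stereo elements differ; a stereocentre at a saturated ring carbon is drawn S in compound 3 and R in compound 4 and nothing more: the two compounds have the same atoms and bonds, and a stereocentre at a saturated ring carbon is drawn S in compound 3 and R in compound 4. Within the data shown here, no measured pair shows the effect of such a change, so the data give no direction for it. Among the measured compounds shown here, the only guide is the band itself, with compound 1 at 100 mL/min/kg and compound 2 at 117 mL/min/kg both within the scatter of compound 3. The estimated change is a 1.2-fold lower number from compound 3 to compound 4 (0.06 log units; within the scatter) and it is expected to stay within the scatter. For compound 4 the expected value is 130 mL/min/kg with 75 mL/min/kg to 210 mL/min/kg as the estimated range.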

Compound 4, clearance: 383 mL/min/kg
Compound 4: middle estimate off by 2.9-fold (0.47 log units), on the low side; the measured number lies above the stated range.
By their numbers in this assay, from the lowest: compounds 1, 2 and 3 (each within the scatter of the next); then compound 4.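

In this assay, among these compounds, the stereocentre at a saturated ring carbon is the first single place with a measured step: going from S as drawn to R as drawn gives a 2.6-fold higher number from compound 3 to compound 4 (0.41 log units; beyond the scatter). Configuration at this one position is therefore enough to move the read-out beyond the scatter, with the faster removal on the R side, something the earlier compounds could not show, as no two of them differ in only one place. The step can be assigned to this stereocentre alone because nothing else separates the pair: the fact that compounds 3 and 4 differ only in the configuration as drawn.

Among the compounds shown here, a single pair leaves open whether inverting this stereocentre would give a step of similar direction and size on another core, and the second stereo element, drawn the same in compound 3 and compound 4, has no step of its own. Also open, on these data alone, is whether the gap between the S and R forms would persist if the trifluoromethyl group gave way to another group, such as an amine or a carboxylic acid.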